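Ether substituent step from compound 3 to compound 4

The source may hold more compounds than are shown below. What is called first, only, known or untested is meant among the compounds shown, and "the series" means these compounds.

Among the compounds with values here, compound 3 `C=CC(=O)NCc1coc(-c2c(N)ncnc2Nc2ccc(Oc3cc(Cl)ccc3Cl)c(Cl)c2)n1` gives 0.85 h in an in vitro ADME assay on microsomes from liver (Rattus norvegicus) for metabolic stability, tested at 5 uM (on this read-out higher numbers stand for a longer-lived compound and lower numbers for a shorter-lived compound), the highest of the three numbers so far. Compound 2 `C=CC(=O)NCc1coc(-c2c(N)ncnc2Nc2ccc(OCc3cccc(F)c3)c(Cl)c2)n1` gives 0.483 h in this assay and is the nearest, within the scatter of compound 3. Compound 1 `C=CC(=O)NCc1coc(-c2c(N)ncnc2Nc2ccc(OCc3ccccn3)c(F)c2)n1` gives 0.267 h in this assay and is the furthest, beyond the scatter of compound 3.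

Compound 4 `C=CC(=O)NCc1coc(-c2c(N)ncnc2Nc2ccc(Oc3ccccn3)c(Cl)c2)n1` differs from compound 3 in one place: pyridin-2-yl in place of 2,5-dichlorophenyl on an oxygen on an aromatic ring. Within the data shown here, the only measured step at that oxygen is a 1.8-fold higher number from compound 2 to compound 3 (0.25 log units; within the scatter), which exchanged a 3-fluorobenzyl for an aryl group and stayed within the scatter. Among the measured compounds shown here, the present step exchanges one aryl group for another, smaller one carrying a ring nitrogen; no measured pair covers exactly that exchange. Compound 1 also carries a pyridine at the ether oxygen, but it differs from compound 3 in two places, so its lower number cannot be tied to the ether change alone and only hints at a direction.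

Compound 4 is therefore expected to give a modestly lower number than compound 3, estimated at 0.45 h with a range of 0.2 h to 0.9 h. The expected step from compound 3 to compound 4 in this assay is a 1.9-fold lower number from compound 3 to compound 4 (0.28 log units; within the scatter), not clearly beyond the scatter.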

Compound 4, half-life: 0.267 h
Estimate against measurement, compound 4: 1.7-fold (0.23 log units) above, within the range that was stated.
By their numbers in this assay, from the lowest: compounds 1, 4, 2 and 3 (each within the scatter of the next, the first and the last beyond it).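

Within the data shown here, the exchange of 2,5-dichlorophenyl for pyridin-2-yl on this oxygen gives a 3.2-fold lower number from compound 3 to compound 4 (0.50 log units; beyond the scatter) in this assay and is the first step at this position to lie beyond the scatter, which shows that the read-out can respond to a change from one aryl group to another. The exchange of 3-fluorobenzyl for pyridin-2-yl at the same place gives a 1.8-fold lower number from compound 2 to compound 4 (0.26 log units; within the scatter) and stays within the scatter, so an aryl group directly on the oxygen does not by itself set compound 4 apart from compound 2. Nothing at hand accounts for the size of either step.

Going by these compounds, the step from compound 3 to compound 4 removes two chlorine atoms and adds a ring nitrogen at once, so it remains open which of these changes goes with the lower number, and an unsubstituted phenyl or a chloropyridinyl group on the same oxygen would separate the two. Also open, on these data alone, is how this assay would respond to an amine or a carboxylic acid on the ring at this oxygen, or to a longer chain between that ring and the oxygen.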